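A few compounds are considered here, and "the series" means these few. Any claim that something is new, unique, unknown or untested is made for them only; others in the source may bear on it.

Compound 1 `CC[C@H](C)[C@H](N)CN(C(=O)[C@@H]1C[C@H]1c1ccccc1)c1ccc(-c2ccc(COC)cc2)cc1` gives 35 nM in a functional assay for agonist activity at G protein-coupled receptor 88 (Homo sapiens), read by HTRF and cAMP accumulation; a lower number here means that less compound is needed, a higher number that more compound is needed for the effect. Compound 2 `CCOC(=O)c1ccc(-c2ccc(N(C[C@@H](N)[C@@H](C)CC)C(=O)[C@@H]3C[C@H]3c3ccccc3)cc2)cc1` gives 260 nM in this assay, the higher of the two numbers; the step of a 7.4-fold higher number from compound 1 to compound 2 (0.87 log units; beyond the scatter) is the only one measured. Compound 3 `CC[C@H](C)[C@H](N)CN(C(=O)[C@@H]1C[C@H]1c1ccccc1)c1ccc(-c2ccc(C(=O)N(C)C)cc2)cc1` carries dimethylamino in place of ethoxy on a carbonyl carbon. Among the compounds with values here, no measured step exchanges one substituent for another on the carbonyl carbon, so the single step measured is a loose guide at best. The expected step for compound 3 in this assay is a 1.2-fold lower number from compound 2 to compound 3 (0.07 log units; within the scatter), with no change beyond the scatter foreseen. Compound 3 is estimated at 220 nM, range 60 nM to 800 nM.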

Compound 3, half-maximal effective concentration: 980 nM
Estimate against measurement, compound 3: 4.5-fold (0.65 log units) below; the whole stated range lies below it.
By their numbers in this assay, from the lowest: compound 1; then compound 2; then compound 3.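

On the carbonyl carbon the substituent counts, not the carbonyl alone: dimethylamino in place of ethoxy gives a 3.8-fold higher number from compound 2 to compound 3 (0.58 log units; beyond the scatter) in this assay and so moves the number beyond the scatter. Set against the methoxymethyl of compound 1, dimethylcarbamoyl on the aromatic carbon gives a 28-fold higher number from compound 1 to compound 3 (1.45 log units; beyond the scatter) and stands at the high end of the three compounds. No available data bear on the cause of either step. Open, on these data alone, is how a plain amino or methylamino group on the same carbonyl carbon would read. As far as these compounds go, a carboxylic acid at this place also remains open.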